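Pendant aryl replacement and maximal response at the bile acid receptor

The source may report more compounds than this note shows. Statements on the series, on what has been measured and on what is new or still open speak of the compounds shown alone.

Within the data shown here, compound 1 `Cc1ccccc1-n1nc(C)c2c1NC(=O)[C@H](C)S[C@@H]2c1ccc(-c2ccoc2)cc1` stands at the lower end of the two numbers so far in an assay on isolated protein for agonist activity at Bile acid receptor (Homo sapiens), read by AlphaScreen, with a stated time of 30 min (a higher number here means a larger maximal response, a lower number a smaller maximal response), where compound 1 gives 40%. Among the measured compounds shown here, the only other measured member, compound 2 `CCc1ccccc1-n1nc(C)c2c1NC(=O)[C@H](C)S[C@@H]2c1ccc(Oc2ccccc2)cc1`, gives 190% in this assay; the two compounds differ in more than one place, so their values are read side by side rather than as a single step, and the gap between them is beyond the usual scatter.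

Compound 3 `CCOc1cccc(-c2ccc([C@H]3S[C@@H](C)C(=O)Nc4c3c(C)nn4-c3ccccc3C)cc2)c1` keeps the shared core of compound 1 and changes the group on the aromatic carbon para to a large group: 3-ethoxyphenyl in place of furan-3-yl on an aromatic carbon. The furan-3-yl leaves and a 3-ethoxyphenyl enters, a six-membered aromatic ring of carbon only in place of the five-membered aromatic ring with one hetero atom.

For the measured compounds named here, no step between measured compounds covers this change. An upward step is nonetheless expected because compound 2 gives 190% while carrying a larger six-membered aromatic ring of carbon only with one oxygen, although compound 2 differs elsewhere too, so only part of that gap is expected. The expected step is a number 70 percentage points higher from compound 1 to compound 3 (beyond the scatter). Compound 3 is estimated at 110% in this assay, within 50% to 200%.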

Compound 3, largest response reached (reported as efficacy), in percent of the reference or control that the assay uses: 13%
Estimate against measurement, compound 3: 97 percentage points above; the measured number lies below the stated range.
By their numbers in this assay, from the lowest: compound 3; then compound 1; then compound 2.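

Among these compounds, replacing furan-3-yl with 3-ethoxyphenyl on the aromatic carbon para to a large group gives the first single-place reading at this position: in this assay the response moves a number 27 percentage points lower from compound 1 to compound 3 (beyond the scatter) and lands at the bottom of the three numbers. The change enlarges the group from 5 to 9 heavy atoms and swaps a five-membered aromatic ring with one hetero atom for a six-membered aromatic ring of carbon only, while the counts of hydrogen-bond donors and acceptors and the net charge stay the same, so a larger aryl group at this carbon does not by itself bring a larger maximal response. No measurement at hand explains the fall.

The compounds shown leave open whether the lower response goes with the six-membered ring itself or with the ethoxy group on it, a question that a plain phenyl or a 3-aminophenyl at this carbon would address. Also open, going by these compounds, is whether the phenoxy group of compound 2 at 190% would keep a high response on the core of compound 1, as compound 2 differs from it in more than one place.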